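Taking the Chlorine Off Compound 3

A few compounds are considered here, and "the series" means these few. Any claim that something is new, unique, unknown or untested is made for them only; others in the source may bear on it.

Measured in a functional assay on NCI-H460 cells (Homo sapiens) for inhibition, read by sulforhodamine B assay, with a stated time of 48 h (on this read-out higher numbers stand for weaker inhibition of growth and lower numbers for stronger inhibition of growth), so far:
- Compound 1 `CCOC(=O)c1nn(-c2ccc(Cl)cc2)c(-c2ccccc2)c1CNC(C)(C)C` gives > 608000 nM; > 559000 nM (2 entries) as limits
- Compound 2 `CC(C)(C)NCc1c(C(=O)O)nn(-c2ccc(Cl)cc2)c1-c1ccc(F)cc1` gives > 623000 nM as a limit
- Compound 3 `CC(C)(C)NCc1c(C(=O)O)nn(-c2ccc(Cl)cc2)c1-c1ccc(Cl)cc1` gives > 599000 nM as a limit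

These entries are limits of the assay and not numbers. Compound 1 has two entries, and both are limits. Compound 3 stands with only its limit of > 599000 nM to show, and it has no single number.

Compound 4 `CC(C)(C)NCc1c(C(=O)O)nn(-c2ccc(Cl)cc2)c1-c1ccccc1` shares the core of compound 3 and has yet to be measured. Its 4-chlorophenyl becomes phenyl, a change counted as hydrogen in place of chloro on an aromatic carbon and read as hydrogen in place of chloro on an aromatic carbon, para to a large group.

For the measured compounds named here, the only measured step that bears on this change is a step that the two limits leave unreadable from compound 2 to compound 3 and it offers neither a size nor a direction, so no step beyond the scatter is expected in this assay here. Compound 4 is expected to return only a limit as well. The estimate means a step that the limit leaves unreadable from compound 3 to compound 4 as the expected outcome. Compound 4 is estimated at 650000 nM with an expected range from 400000 nM to 800000 nM on the same read-out.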

Compound 4, concentration for 50% growth inhibition: > 652000 nM
Compound 4 was reported as a limit (the forecaster's own chance of this, stated with the estimate: 90%); middle value at least 1.0-fold (0.00 log units) from the limit.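

In this assay, compound 4 returns only a limit, as do compound 2 and compound 3, so no step can be read among these three compounds, whether the change is between hydrogen, fluoro or chloro. The compounds shown leave open whether any of these changes affects growth inhibition at all.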